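The compounds below may be only part of what the source reports. "The series", "measured", "known", "first", "only" and "open" are said of these compounds alone.

Measured so far:
compound 2 `COc1ccc(CS(=O)(=O)/C=C/c2c(OC)cccc2OC)cc1N` — 60 nM
compound 3 `COc1cc(OC)c(/C=C/[S+]([O-])Cc2ccc(OC)c(N)c2)c(OC)c1` — < 10 nM
compound 1 `COc1cc(OC)c(/C=C/S(=O)(=O)Cc2ccc(OC)c([N+](=O)[O-])c2)c(OC)c1` — "not determined" (no result reported)

Of the compounds shown here, three have been tested in a functional assay on MDA-MB-468 cells (Homo sapiens) for cytotoxicity, read by MTT assay, with a stated time of 72 h (a higher number here means a weaker inhibitor of growth, a lower number a stronger inhibitor of growth), though only two gave a readable outcome. For the measured compounds named here, compound 2 `COc1ccc(CS(=O)(=O)/C=C/c2c(OC)cccc2OC)cc1N` gives 60 nM in this assay; this is the only plain number among the three. Compound 3 `COc1cc(OC)c(/C=C/[S+]([O-])Cc2ccc(OC)c(N)c2)c(OC)c1` reaches the limit of this assay, < 10 nM, which is a boundary of the measurement rather than a number; the evidence shows (the limit of < 10 nM in this assay, at which 1 of the 3 values shown sits). Compound 1 `COc1cc(OC)c(/C=C/S(=O)(=O)Cc2ccc(OC)c([N+](=O)[O-])c2)c(OC)c1` has no reported result in this assay, "not determined" (no result reported). Since no pair of these compounds differs in just one place, no measured step is available to guide expectations.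

The next compound, compound 4 `COc1ccc(CS(=O)(=O)/C=C/c2c(OC)cccc2OC)cc1[N+](=O)[O-]`, differs from compound 2 in one place: nitro in place of amino on an aromatic carbon. Going by the values given here, with no measured step of this kind, the size and direction of the effect have to be guessed. The expectation is a moderate step in this assay toward weaker inhibition of growth, a 5.0-fold higher number from compound 2 to compound 4 (0.70 log units; beyond the scatter), beyond the usual scatter. Compound 4 is therefore estimated at 300 nM, in a range from 60 nM to 2000 nM.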

Compound 4, concentration for 50% growth inhibition: 5460 nM
Beside the measured number, compound 4's estimate is 18-fold (1.26 log units) below it, outside the stated range (above it).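

Within this assay, the aromatic carbon ortho to a methoxy group proves highly sensitive to what it carries: nitro in place of amino gives a 91-fold higher number from compound 2 to compound 4 (1.96 log units; beyond the scatter). For the compounds shown here, this is the first single-place comparison in the set, so it is the first direct sign that the choice of group at this position can change the read-out by a large margin. The swap replaces a group with 1 hydrogen-bond donor by one with 0 hydrogen-bond donors and raises the count from 1 heavy atom to 3, but no measurement shown here links either difference to the loss of growth inhibition.

On these data alone, one swap cannot show which feature of the two groups matters, so it remains open whether a hydroxyl group, a methylamino group or an acetamide at this carbon would stay close to compound 2 or move toward compound 4. As far as these compounds go, it also remains open whether the step carries over to the other cores, since compound 1, which also bears nitro, stands at "not determined" (no result reported) and offers no second reading.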